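Swapping a Sulfonyl Cap for a Carbonyl Cap

The source may report more compounds than this note shows. Statements on the series, on what has been measured and on what is new or still open speak of the compounds shown alone.

Of the compounds shown here, three built on one shared core have been tested in a functional assay on A-375 cells (Homo sapiens) for cytotoxicity, read by MTT assay; a lower number here means a stronger inhibitor, a higher number a weaker inhibitor. Compound 1 `O=S(=O)(NCCCNc1nccc(-c2c(-c3cccc(F)c3)nc3sccn23)n1)c1cccc(F)c1` gives 13700 nM. Compound 2 `O=S(=O)(NCCCNc1nccc(-c2c(-c3cccc(F)c3)nc3sccn23)n1)c1ccc(Cl)cc1` gives 5900 nM, and compound 3 `O=C(NCCCNc1nccc(-c2c(-c3cccc(F)c3)nc3sccn23)n1)c1ccc(Cl)cc1` gives 13700 nM. On these numbers compound 1 sits level with compound 3, and together they hold the highest figure of the three; the only separation seen is a 2.3-fold lower number from compound 1 to compound 2 (0.37 log units; beyond the scatter).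

Compound 4 `O=C(NCCCNc1nccc(-c2c(-c3cccc(F)c3)nc3sccn23)n1)c1ccc(F)cc1` has not yet been measured. It differs from compound 1 in a single place: (4-fluorophenyl)carbonyl in place of (3-fluorophenyl)sulfonyl on an amine nitrogen. Two measured steps speak to this move. Exchanging the linking group alone, with the same ring substituent on each side, produced no change at the digits printed from compound 1 to compound 3 (within the scatter), and the reverse kind of exchange on a different ring gave a 2.3-fold higher number from compound 2 to compound 3 (0.37 log units; beyond the scatter). Changing only the ring substituent gave a 2.3-fold lower number from compound 1 to compound 2 (0.37 log units; beyond the scatter). The step to compound 4 combines a linking-group change that left the number unmoved with a shift of a fluorine substituent for which no direct comparison exists on a carbonyl. I therefore expect in this assay little movement, most likely nothing beyond the scatter, with any drift more likely downward than upward.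

For compound 4 the expected value in this assay is 11000 nM, with a range from 4500 nM to 28000 nM. That estimate corresponds to an expected step of a 1.2-fold lower number from compound 1 to compound 4 (0.10 log units; within the scatter).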

Compound 4, half-maximal inhibitory concentration: 14900 nM
The estimate for compound 4 lay 1.4-fold (0.13 log units) below the measured number, within the range that was stated.
By their numbers in this assay, from the lowest: compound 2; then compounds 1, 3 and 4 (each within the scatter of the next).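

In this assay the carbonyl cap now has a direct comparison of ring substituents: fluoro in place of chloro on an aromatic carbon gives a 1.1-fold higher number from compound 3 to compound 4 (0.04 log units; within the scatter) and so does not register on this cap. Placing (4-fluorophenyl)carbonyl on the amine nitrogen in place of (3-fluorophenyl)sulfonyl gives a 1.1-fold higher number from compound 1 to compound 4 (0.04 log units; within the scatter) and in place of (4-chlorophenyl)sulfonyl gives a 2.5-fold higher number from compound 2 to compound 4 (0.40 log units; beyond the scatter) so compound 2 alone stands apart from the other three, while compound 1 shows that a sulfonyl cap by itself does not bring that separation. No measured evidence is available here to explain these numbers.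

The compounds shown leave open how a (4-fluorophenyl)sulfonyl cap would compare with compound 2 and compound 4, which would test whether the chloro group matters on the sulfonyl side. They also leave open whether a methoxy group on the ring, or a longer chain on the amine nitrogen in place of the present one, would move the number beyond the scatter.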